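The source may report more compounds than this note shows. Statements on the series, on what has been measured and on what is new or still open speak of the compounds shown alone.

Compound 3 `CC(C)C[C@H](N)c1cc(C(F)(F)F)ccc1N1CCN(C(=O)COc2cccc(Cl)c2Cl)CC1` stands highest of the two numbers recorded in an assay on HEK293 cells for displacement of a labelled ligand from Melanocortin receptor 4 (Homo sapiens); a higher number here means a weaker inhibitor, a lower number a stronger inhibitor: compound 2 `CC(C)C[C@H](N)c1cc(C(F)(F)F)ccc1N1CCN(C(=O)C(C)Cc2ccc(Cl)cc2O)CC1` gives 36 nM, and the step of a 69-fold higher number from compound 2 to compound 3 (1.84 log units; beyond the scatter) separates them, leaving compound 3 at 2500 nM. Compound 1 `CC(C)C[C@H](N)c1cc(C(F)(F)F)ccc1N1CCN(C(=O)CCC(N)=O)CC1` reaches only the limit of > 10000 nM in this assay. From that limit, an at least 270-fold lower number from compound 1 to compound 2 (2.44 log units; beyond the scatter) and an at least 4.0-fold lower number from compound 1 to compound 3 (0.60 log units; beyond the scatter) describe the gains brought by the two aromatic groups placed on the carbonyl carbon. Compound 4 `COc1ccc(CC(C)C(=O)N2CCN(c3ccc(C(F)(F)F)cc3[C@@H](N)CC(C)C)CC2)cc1F` differs from compound 3 in one place: 1-(3-fluoro-4-methoxybenzyl)ethyl in place of (2,3-dichlorophenoxy)methyl on a carbonyl carbon. The measured step that bears most on this change is a 69-fold higher number from compound 2 to compound 3 (1.84 log units; beyond the scatter), in which a 1-(4-chloro-2-hydroxybenzyl)ethyl gave way to a (2,3-dichlorophenoxy)methyl and the number rose sharply; compound 4 brings back a benzyl-ethyl arrangement, though its ring carries a fluorine and a methoxy rather than the chlorine and hydroxyl of compound 2. A large fall in the number is therefore expected, most of the way back toward compound 2 but not necessarily all of it. Compound 4 is estimated at 150 nM in this assay, between 30 nM and 800 nM, an expected step of a 17-fold lower number from compound 3 to compound 4 (1.22 log units; beyond the scatter).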

Compound 4, inhibition constant: 200 nM
Compound 4: the middle estimate sits 1.3-fold (0.12 log units) below what was measured; low and high end bracket the measured number.
By their numbers in this assay, from the lowest: compound 2; then compound 4; then compound 3. At a limit, above all of these: compound 1.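

Placed on the carbonyl carbon in this assay, 1-(3-fluoro-4-methoxybenzyl)ethyl in place of (2,3-dichlorophenoxy)methyl gives a 13-fold lower number from compound 3 to compound 4 (1.10 log units; beyond the scatter), so a large gain over the phenoxy group does not depend on the 4-chloro-2-hydroxyphenyl ring of compound 2. The ring still matters: 3-fluoro-4-methoxyphenyl in place of 4-chloro-2-hydroxyphenyl, with the chain unchanged, gives a 5.6-fold higher number from compound 2 to compound 4 (0.74 log units; beyond the scatter). The remaining step, an at least 50-fold lower number from compound 1 to compound 4 (1.69 log units; beyond the scatter), rests on a limit and gives only a minimum: the limit of > 10000 nM in this assay, at which 1 of the 4 values shown sits.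

Which ring substituent accounts for the modest difference stays open, as fluorine, methoxy, chlorine and hydroxyl all change together. The compounds shown also leave open how an amine or a carboxylic acid on that ring, or a longer chain leading to it, would fare.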